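Replacing the sulfonyl aryl group: from fluorine to nitrile

The source may report more compounds than this note shows. Statements on the series, on what has been measured and on what is new or still open speak of the compounds shown alone.

Three compounds share one core and differ only in the aryl group on the sulfonyl sulfur. In an assay on isolated protein for displacement of a labelled ligand from metabotropic glutamate receptor 5 (Homo sapiens), with a stated time of 60 min, tested at 1 uM (on this read-out lower numbers stand for less inhibition and higher numbers for more inhibition at the one concentration tested (going by the name of the read-out)), compound 3 `CC1CCN(c2c(S(=O)(=O)c3cccc(F)c3)cnc3c(F)cccc23)CC1` gives 62% and stands highest, with compound 2 `CC1CCN(c2c(S(=O)(=O)c3ccccc3)cnc3c(F)cccc23)CC1` at 13% and compound 1 `CC1CCN(c2c(S(=O)(=O)c3cc(F)cc(F)c3)cnc3c(F)cccc23)CC1` at 9%. The steps of a number 49 percentage points higher from compound 2 to compound 3 (beyond the scatter) and a number 53 percentage points higher from compound 1 to compound 3 (beyond the scatter) are large, while a number 4 percentage points higher from compound 1 to compound 2 (within the scatter) is within the scatter. Compound 4 `CC1CCN(c2c(S(=O)(=O)c3ccc(C#N)cc3)cnc3c(F)cccc23)CC1` carries 4-cyanophenyl in place of 3-fluorophenyl on a sulfonyl sulfur. The 3-fluorophenyl that gave compound 3 its high reading is lost, and both measured compounds without it sit far lower, so a drop is expected: a number 42 percentage points lower from compound 3 to compound 4 (beyond the scatter). Compound 4 is therefore estimated at 20%, with a range from 5% to 50%.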

Compound 4, a percentage reported as inhibition, at one concentration (the size of the read-out at that concentration, not a potency): 86%
Beside the measured number, compound 4's estimate is 66 percentage points below it, outside the stated range (above it).
By their numbers in this assay, from the lowest: compounds 1 and 2 (each within the scatter of the next); then compound 3; then compound 4.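

In this assay the sulfonyl aryl group can read higher than with 3-fluorophenyl, as 4-cyanophenyl gives a number 24 percentage points higher from compound 3 to compound 4 (beyond the scatter) in a modest but real gain. Set against the other two rings, the change is much larger, with a number 73 percentage points higher from compound 2 to compound 4 (beyond the scatter) for adding cyano to the plain phenyl and a number 77 percentage points higher from compound 1 to compound 4 (beyond the scatter) for replacing 3,5-difluorophenyl, so a single substituent on this ring can decide the reading. No measurement available here explains why the nitrile reads so high.

The compounds shown leave open whether a 3-cyanophenyl would read as high as 4-cyanophenyl. They also leave open whether a methoxy group or a carboxylic acid in place of the nitrile would hold the reading.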